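Aryl substituent swap on the shared core: compound 2 to compound 4

The source may hold more compounds than are shown below. What is called first, only, known or untested is meant among the compounds shown, and "the series" means these compounds.

For the measured compounds named here, in an assay on isolated protein for inhibition of ubiquitin carboxyl-terminal hydrolase 7 (Homo sapiens), with stated times of 30 min and 2 h (a lower number here means a stronger inhibitor, a higher number a weaker inhibitor), compound 2 `Cn1nc2c(=O)n(CC3(O)CCN(Cc4ccc(-c5ccco5)cc4Cl)CC3)cnc2c1-c1ccc(F)cc1` gives 64.5 nM, the lowest of the three numbers so far, though compound 1 `Cn1nc2c(=O)n(CC3(O)CCN(Cc4ccc(-c5ccco5)cc4Cl)CC3)cnc2c1-c1ccc(CNS(C)(=O)=O)cc1` at 65.3 nM and compound 3 `Cn1nc2c(=O)n(CC3(O)CCN(Cc4ccc(C5=CCCC5)cc4Cl)CC3)cnc2c1-c1ccc(CN)cc1` at 76.9 nM both lie within the scatter of it. Compound 4 `CCCNCc1ccc(-c2c3ncn(CC4(O)CCN(Cc5ccc(-c6ccco6)cc5Cl)CC4)c(=O)c3nn2C)cc1` carries (propylamino)methyl in place of fluoro on an aromatic carbon. Going by the values given here, the one measured step that bears on this position, a 1.0-fold lower number from compound 1 to compound 2 (0.01 log units; within the scatter), shows fluoro and (methanesulfonamido)methyl giving the same number. Compound 3, with aminomethyl on this aryl ring but a different group on the other ring, also gives a number no different beyond the scatter. A (propylamino)methyl group is therefore expected to leave the number essentially unchanged, a 1.0-fold higher number from compound 2 to compound 4 (0.00 log units; within the scatter). Compound 4 is estimated at 65 nM, between 30 nM and 140 nM.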

Compound 4, half-maximal inhibitory concentration: 43.9 nM
Beside the measured number, compound 4's estimate is 1.5-fold (0.17 log units) above it, within the range that was stated.
By their numbers in this assay, from the lowest: compounds 4, 2, 1 and 3 (each within the scatter of the next).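

In this assay, the position para to a large group takes (propylamino)methyl in place of fluoro with no change beyond the scatter (a 1.5-fold lower number from compound 2 to compound 4 (0.17 log units; within the scatter)). On the amine nitrogen, propyl in place of methylsulfonyl also stays within the scatter (a 1.5-fold lower number from compound 1 to compound 4 (0.17 log units; within the scatter)), so this series shows no separation between the amine and the sulfonamide at this position. Nothing at hand accounts for these results.

From the compounds shown here alone, whether a longer chain on that amine nitrogen would move the number beyond the scatter remains open. The same holds for a carboxylic acid on this aromatic carbon.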